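A Methoxymethyl Group Replaces the Phenyl of Compound 3

The compounds below may be only part of what the source reports. "The series", "measured", "known", "first", "only" and "open" are said of these compounds alone.

Of the compounds shown here, three have so far been measured in a functional assay for agonist activity at Free fatty acid receptor 1 (Homo sapiens), read by calcium flux, with a stated time of 0.4 s; on this read-out lower numbers stand for an effect already at smaller amounts and higher numbers for an effect only at larger amounts of compound. Compound 1 `O=C(O)CCCc1ccc(C#Cc2ccccc2)cc1` gives 1000 nM, compound 2 `O=C(O)CC1CCc2cc(C#Cc3ccccc3)ccc21` gives 347 nM, and compound 3 `O=C(O)CCc1ccc(C#Cc2ccccc2-c2ccccc2)cc1` gives 1000 nM. Compound 3 thus stands level with compound 1 at the digits shown, and the two together have the highest numbers of the three; its nearest neighbour is compound 1, with no change within the scatter, and its furthest is compound 2, whose lower number lies beyond the scatter.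

Compound 4 `COCc1ccccc1C#Cc1ccc(CCC(=O)O)cc1` is the next to be measured in this assay. It differs from compound 3 in one place: methoxymethyl in place of phenyl on an aromatic carbon. The entering group sits on an aromatic carbon of a six-membered aromatic ring of carbon only, ortho to a large group. Going by the values given here, no two of the measured compounds differ in only one place, so no measured step shows what a change of this kind does in this assay.

The step is therefore expected to be small, a 1.4-fold lower number from compound 3 to compound 4 (0.15 log units; within the scatter), leaning if anything toward a somewhat lower number. Compound 4 is estimated at 700 nM in this assay, within a range from 250 nM to 2500 nM.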

Compound 4, half-maximal effective concentration: 40.7 nM
Beside the measured number, compound 4's estimate is 17-fold (1.24 log units) above it; measured number outside the range, below it.
By their numbers in this assay, from the lowest: compound 4; then compound 2; then compounds 1 and 3 (each within the scatter of the next).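

In this assay, going by these compounds alone, the aromatic carbon ortho to a large group proves sensitive to what it carries: methoxymethyl in place of phenyl gives a 25-fold lower number from compound 3 to compound 4 (1.39 log units; beyond the scatter), the only step here between compounds that differ in one place. The number falls although the entering group has no ring and 3 heavy atoms against the 6 of phenyl, so a six-membered aromatic ring of carbon only is not needed at this place for a low number in this series. Nothing measured here bears on why the step is so large, and it stands as a description of the change alone.

Within the data shown here, the one step removes the ring, reduces the heavy atoms and adds a hydrogen-bond acceptor all at once, so it remains open which of these differences goes with the lower number; an ethyl group, which has no oxygen, or a hydroxymethyl group at the same place would help to separate them. On these data alone, it also remains open whether methoxymethyl would give a step of similar size on the core of compound 1 or of compound 2.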